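Hydroxy for trifluoromethyl on two cores of one series

The compounds below may be only part of what the source reports. "The series", "measured", "known", "first", "only" and "open" are said of these compounds alone.

Compound 1 `CC(C)=CCC/C(C)=C/CC/C(C)=C/CC[C@@H]1[C@@]2(C)CC/C(=N\OCc3cn(-c4cccc(C(F)(F)F)c4)nn3)C(C)(C)[C@@H]2CC[C@@]1(C)O` and compound 2 `CC(C)=CCC/C(C)=C/CC/C(C)=C/CC[C@@H]1[C@@]2(C)CC/C(=N\OCc3cn(-c4cccc(O)c4)nn3)C(C)(C)[C@@H]2CC[C@@]1(C)O` share a core and differ only in the group on the aromatic carbon of the outer ring. In a functional assay on HeLa cells (Homo sapiens) for cytotoxicity, read by MTT assay, with a stated time of 48 h (a higher number here means a weaker inhibitor, a lower number a stronger inhibitor), compound 1 gives 12500 nM, and compound 2 gives 13500 nM. The change between them is hydroxy in place of trifluoromethyl on an aromatic carbon; its step is a 1.1-fold higher number from compound 1 to compound 2 (0.03 log units; within the scatter), so the pair does not separate in this assay.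

Compound 3 `CC(C)=CCC/C(C)=C/CC/C(C)=C/CC[C@@H]1[C@@]2(C)C/C(=C\c3ccc(OCc4cn(-c5cccc(C(F)(F)F)c5)nn4)cc3)C(=O)C(C)(C)[C@@H]2CC[C@@]1(C)O` is built on a different core; how the two cores differ is not broken down here. In this assay compound 3 gives 17300 nM. Its gaps to compound 2 and to compound 1 are both within the scatter, so the three measured compounds sit at one level.

Compound 4 `CC(C)=CCC/C(C)=C/CC/C(C)=C/CC[C@@H]1[C@@]2(C)C/C(=C\c3ccc(OCc4cn(-c5cccc(O)c5)nn4)cc3)C(=O)C(C)(C)[C@@H]2CC[C@@]1(C)O`, not yet measured, carries the change hydroxy in place of trifluoromethyl on an aromatic carbon on the core of compound 3. The place and the groups are the same as in the step from compound 1 to compound 2, so this is the same change on a second core.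

The expectation for compound 4 in this assay rests on the earlier step, because a 1.1-fold higher number from compound 1 to compound 2 (0.03 log units; within the scatter) shows no movement from this change on the first core; the step from compound 3 to compound 4 is estimated as a 1.1-fold higher number from compound 3 to compound 4 (0.04 log units; within the scatter). Compound 4 is expected to give about 19000 nM in this assay, estimated within 9000 nM to 40000 nM.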

Compound 4, half-maximal inhibitory concentration: 158000 nM
Estimate against measurement, compound 4: 8.3-fold (0.92 log units) below; measured number above the stated range.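

On the second core, hydroxy in place of trifluoromethyl is not a silent change in this assay: the step is a 9.1-fold higher number from compound 3 to compound 4 (0.96 log units; beyond the scatter), a shift beyond the scatter towards a weaker inhibitor, whereas on the first core the same change is a 1.1-fold higher number from compound 1 to compound 2 (0.03 log units; within the scatter). For the compounds shown here, the result for this change on one core therefore does not carry over to the other, as the two steps differ in size by more than the scatter allows: the same change on two cores in this assay, a 1.1-fold higher number (0.03 log units; within the scatter) from compound 1 to compound 2 and a 9.1-fold higher number (0.96 log units; beyond the scatter) from compound 3 to compound 4, 8.5-fold (0.93 log units) apart, beyond the scatter of two such steps This shows that the outcome of the change depends on the core it sits on, but with only one pair per core it does not show which feature of the cores is responsible, nor whether any other change at this place would depend on the core in the same way.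

The compounds shown leave open whether the shift on the second core is tied to hydroxy itself or to the loss of trifluoromethyl, a question that methoxy, chlorine or an amine at the same place on both cores could address. On these data alone, it also remains open whether an unsubstituted phenyl on each core would side with 3-hydroxyphenyl or with 3-(trifluoromethyl)phenyl.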